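Changing the amine on compound 2

The source may hold more compounds than are shown below. What is called first, only, known or untested is meant among the compounds shown, and "the series" means these compounds.

Values in an ADME assay on microsomes from liver (Rattus norvegicus) for metabolic stability, read by LC-MS, using NADPH, with a stated time of 1 h, tested at 10 uM (on this read-out higher numbers stand for a longer-lived compound and lower numbers for a shorter-lived compound), for the series so far:
- compound 1 `Cn1nc(CN2CCCC2)nc1-c1ccc(C2(C(F)(F)F)CC2)cc1` gives 0.055 h as half-life
- compound 2 `Cn1nc(CN2CCCC2)nc1-c1ccc(C(C)(C)C)cc1` gives 0.16 h as half-life
- compound 3 `CN(Cc1nc(-c2ccc(C(C)(C)C)cc2)n(C)n1)CC1CC1` is not yet measured

Compound 2 stands highest of the two measured compounds. Compound 3 differs from compound 2 in one place, with (cyclopropylmethyl)(methyl)amino in place of pyrrolidin-1-yl on a saturated chain carbon bound to an aromatic carbon as the whole change. For the measured compounds named here, the only measured step (a 2.9-fold higher number from compound 1 to compound 2 (0.46 log units; beyond the scatter)) concerns a different group, so it gauges size only and no measured step touches the amine. In this assay no step beyond the scatter is expected, with a slight fall as the working guess. The expected step is a 1.5-fold lower number from compound 2 to compound 3 (0.16 log units; within the scatter) on this estimate. Compound 3 is estimated at 0.11 h within an expected range of 0.045 h to 0.26 h as half-life.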

Compound 3, half-life: 0.0583 h
For compound 3 the middle estimate is 1.9-fold (0.28 log units) above the measured one; measured number inside the range.
By their numbers in this assay, from the lowest: compounds 1 and 3 (each within the scatter of the next); then compound 2.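

In this assay the amine on the saturated chain carbon bound to an aromatic carbon is a position that moves the half-life: (cyclopropylmethyl)(methyl)amino in place of pyrrolidin-1-yl gives a 2.7-fold lower number from compound 2 to compound 3 (0.44 log units; beyond the scatter). Of these two amines, pyrrolidin-1-yl gives the longer half-life, and compound 2 remains highest in the series. Nothing at hand explains this step. This single change does not separate the loss of the pyrrolidine ring from the entry of the cyclopropylmethyl group. Going by these compounds, whether a morpholine or a dimethylamino group at this position would match compound 2 remains open.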